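Swapping an Amide Tether for an Ether Chain

The source may report more compounds than this note shows. Statements on the series, on what has been measured and on what is new or still open speak of the compounds shown alone.

This short study concerns a small family of selenocyanate-bearing compounds tested in a functional assay on HepG2 cells (Homo sapiens) for inhibition, read by MTT assay, with a stated time of 48 h; on this read-out higher numbers stand for weaker inhibition and lower numbers for stronger inhibition. Compound 1 `COc1ccc(N(C)c2nc(C)nc3ccccc23)cc1C(=O)NCC[Se]C#N` gives 179 nM in this assay, the highest of the three numbers available and so the weakest inhibition seen. Compound 2 `Cc1nc(N(C)c2ccc([Se]C#N)c(F)c2)c2ccccc2n1` gives 37 nM, and compound 3 `CN(c1ccc([Se]C#N)cc1)c1nc(C2CC2)nc2ccccc12` gives 41 nM; both carry the selenocyanate directly on the aromatic ring rather than at the end of a chain, and both sit well beyond the usual scatter from compound 1.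

The next compound to be measured is compound 4 `COc1ccc(N(C)c2nc(C)nc3ccccc23)cc1OCCCC[Se]C#N`, which differs from compound 1 in one place. a group of 8 heavy atoms (5 carbon, 1 nitrogen, 1 oxygen, 1 selenium; no ring) in place of a group of 8 heavy atoms (4 carbon, 2 nitrogen, 1 oxygen, 1 selenium; no ring), on an aromatic carbon The amide hydrogen-bond donor is lost, and the chain that carries the selenium grows by one carbon while becoming an ether.

For the measured compounds named here, no pair of already measured compounds shows this exact change, so the step can only be guessed. Because compound 1 sits at 179 nM while the ring-attached analogues sit lower, a modest improvement is expected but nothing large; the step from compound 1 to compound 4 is estimated as a 1.4-fold lower number from compound 1 to compound 4 (0.14 log units; within the scatter), which may fall inside the scatter. Compound 4 is accordingly expected to give about 130 nM in this assay, within a range from 50 nM to 350 nM.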

Compound 4, half-maximal inhibitory concentration: 6460 nM
Compound 4: middle estimate off by 50-fold (1.70 log units), on the low side; measured number above the stated range.
By their numbers in this assay, from the lowest: compounds 2 and 3 (each within the scatter of the next); then compound 1; then compound 4.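

In this assay, this place on the aromatic carbon proves highly sensitive: putting the ether chain where the amide-bearing chain stood gives a 36-fold higher number from compound 1 to compound 4 (1.56 log units; beyond the scatter), although both groups hold 8 heavy atoms and both end in the selenocyanate. The earlier compounds shown here included no pair differing in one place, so they could not show how much the link between the aromatic ring and the selenium-bearing end can matter; a chain ending in selenocyanate does not by itself secure the level of inhibition seen for compound 1. Nothing measured here accounts for this loss of inhibition.

The step changes the linking group and the chain length together, so the compounds shown cannot separate the effect of losing the amide from that of lengthening the chain. An ether chain matching the length of the chain in compound 1, or an amide with a longer chain, would separate those two changes, while a chain ending in an amine or a carboxylic acid would test whether the selenocyanate end is needed at all.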